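Allyloxy for butoxy on the shared core: cytotoxicity notes

The source may hold more compounds than are shown below. What is called first, only, known or untested is meant among the compounds shown, and "the series" means these compounds.

Compound 3 `CCCCOc1nc(N)nc2c1ncn2/C=C1/CC1(CO)CO` carries a butoxy group on the shared core. In an ADME assay on MOLT-3 cells (Homo sapiens) for cytotoxicity, with a stated time of 7 days (on this read-out lower numbers stand for higher toxicity in this test and higher numbers for lower toxicity in this test), compound 3 gives only the limit of the test, > 20000 nM. Compound 2 `Nc1nc(SC2CCCC2)c2ncn(/C=C3/CC3(CO)CO)c2n1` has cyclopentylsulfanyl in that place. In this assay compound 2 likewise gives only a limit, > 20000 nM. The step that the two limits leave unreadable from compound 2 to compound 3 therefore cannot be read in size. Compound 1 `CC(C)CSc1nc(N)nc2c1ncn2/C=C1/CC1(CO)CO` has no result in this assay ("not determined" (no result reported)). Where compound 3 stands is thus set by the limit of > 20000 nM in this assay, at which 2 of the 3 values shown sit, and nothing finer.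

Compound 4 `C=CCOc1nc(N)nc2c1ncn2/C=C1/CC1(CO)CO` differs from compound 3 by vinyl in place of propyl on a saturated chain carbon bound to an oxygen on an aromatic ring. For the measured compounds named here, no measured step bears on this change: the only step in the set, a step that the two limits leave unreadable from compound 2 to compound 3, lies between two limits and gives no size. Given that compound 3 sits at the limit of > 20000 nM in this assay, at which 2 of the 3 values shown sit, compound 4 is expected to remain at the limit as well, so the expected step that the limit leaves unreadable from compound 3 to compound 4 is none beyond the scatter. The estimate for compound 4 in this assay is 40000 nM, with a range from 20000 nM to 100000 nM, most probably reported again only as a limit.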

Compound 4, half-maximal cytotoxic concentration: > 20000 nM
Compound 4 gave a limit, no number; the forecaster's own chance of this, stated with the estimate: 80%; the middle value lies beyond the limit too.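

Compound 4 gives only a limit in this assay, as do compound 2 and compound 3, so no step among these three can be read in size: the limit of > 20000 nM in this assay, at which 3 of the 4 values shown sit.

The compounds shown leave open whether butoxy, allyloxy and cyclopentylsulfanyl on the shared core differ at all in half-maximal cytotoxic concentration.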